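This account rests on a few compounds, and the source may have more. Where it says the series, first, only, none or still open, it means among the compounds named here.

Compound 1 `O=C(O)CC[C@H]1CCc2cc(-c3cc(OC(F)(F)F)ccc3F)ccc2O1` in a functional assay on HEK293 cells for agonist activity at Free fatty acid receptor 1 (Homo sapiens), read by HTRF and inositol phosphate accumulation, with a stated time of 60 min (a lower number here means that less compound is needed, a higher number that more compound is needed for the effect), gives 2100 nM. Compound 3 `COc1cc(OC2CCC2)cc(-c2ccc3c(c2)CC[C@H](CCC(=O)O)O3)c1F` reaches only the limit of this assay, > 10000 nM. Compound 2 `COc1cc(OC2CCC2)cc(-c2ccc3c(c2)CC[C@H]([C@@H]2C[C@H]2C(=O)O)O3)c1F` also reaches only the limit, > 10000 nM. Compound 2 differs from compound 3 by 2-carboxycyclopropyl in place of 2-carboxyethyl on a saturated ring carbon. The step that the two limits leave unreadable from compound 3 to compound 2 cannot be read because the limit of > 10000 nM in this assay, at which 2 of the 3 values shown sit, hides both values. The difference between the core of compound 1 and the core of compound 3 is not broken down here. Compound 4 `O=C(O)[C@@H]1C[C@H]1[C@H]1CCc2cc(-c3cc(OC(F)(F)F)ccc3F)ccc2O1` carries the same change on the core of compound 1: 2-carboxycyclopropyl in place of 2-carboxyethyl on a saturated ring carbon. Among the measured compounds shown here, no measured step tells its size, since the one measured pair sits at the limit on both sides. The step of a 1.1-fold lower number from compound 1 to compound 4 (0.02 log units; within the scatter) is therefore expected to be small, resting only on the measured value of compound 1, 2100 nM. Compound 4 is expected at 2000 nM, from 500 nM to 8000 nM.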

Compound 4, half-maximal effective concentration: > 10000 nM
Compound 4: a limit, no number; the forecaster's own chance of this, stated with the estimate: 25%; middle value at least 5.0-fold (0.69 log units) away from the limit.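

On the core of compound 1, 2-carboxycyclopropyl in place of 2-carboxyethyl on a saturated ring carbon gives an at least 4.7-fold higher number from compound 1 to compound 4 (0.67 log units; beyond the scatter) in this assay. Compound 4 stands at a limit of the assay, > 10000 nM, not at a number, so this step gives only the smallest size the change can have. On the core of compound 3 the same change cannot be read, so nothing shows whether its size carries from one core to the other: the limit of > 10000 nM in this assay, at which 3 of the 4 values shown sit.

Open, from the compounds shown here alone, is whether a longer chain such as 3-carboxypropyl, or a primary amide in place of the carboxylic acid, would give a readable value on the core of compound 1. Also open, going by these compounds, is how other stereoisomers of 2-carboxycyclopropyl would read.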